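The source may report more compounds than this note shows. Statements on the series, on what has been measured and on what is new or still open speak of the compounds shown alone.

Compound 3 `CCCc1cc(O)cc(O)c1Oc1c(Cl)c(O)c(Cl)c2c1C(=O)O[C@@H]2CC` carries the shared core with two hydroxy groups on the propyl-bearing ring. In an ADME assay on MDCK cells (Canis lupus familiaris) for cytotoxicity, read by CellTiter-Glo, with a stated time of 40 h (a higher number here means that more compound is tolerated, a lower number that less compound is tolerated), compound 3 gives > 100000 nM, which is a limit of the assay. Compound 1 `CCCc1c(Cl)c(O)cc(O)c1Oc1c(Cl)c(O)c(Cl)c2c1C(=O)O[C@@H]2CC` carries chloro in place of hydrogen on an aromatic carbon. In this assay compound 1 gives > 50000 nM, also a limit of the assay. Accordingly a step that the two limits leave unreadable from compound 3 to compound 1; what stands behind it is the limit of > 100000 nM in this assay, at which 1 of the 3 values shown sits, and (the limit of > 50000 nM in this assay, at which 2 of the 3 values shown sit). Compound 2 `CCCc1c(Cl)c(OC)cc(OC)c1Oc1c(Cl)c(O)c(Cl)c2c1C(=O)O[C@@H]2CC` bears methoxy groups where compound 3 bears hydroxy groups; the difference between the two cores is not broken down here. In this assay compound 2 gives > 50000 nM, a limit of the assay. Compound 4 `CCCc1c(Cl)c(OC)c(Cl)c(OC)c1Oc1c(Cl)c(O)c(Cl)c2c1C(=O)O[C@@H]2CC` is not yet measured and carries chloro in place of hydrogen on an aromatic carbon. This is the same kind of change as from compound 3 to compound 1, yet the surroundings differ: there the place was ortho to a hydroxy group, ortho to a propyl group and para to a hydroxy group, here it is ortho to two methoxy groups, meta to a chloro group and para to a propyl group. Compound 4 is expected in this assay near 80000 nM, likely between 40000 nM and 200000 nM. The expected step that the limit leaves unreadable from compound 2 to compound 4 is small, resting on the limit of > 50000 nM in this assay, at which 2 of the 3 values shown sit, and (the limit of > 100000 nM in this assay, at which 1 of the 3 values shown sits), which show every measured member tolerated up to the assay limit. A limit rather than a number is expected again.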

Compound 4, half-maximal cytotoxic concentration: > 50000 nM
Compound 4: no number, only a limit; the forecaster's own chance of this, stated with the estimate: 75%; the middle value is on the limit's open side.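

In this assay compound 4 gives > 50000 nM, a limit of the assay, so the step from compound 2 to compound 4 cannot be read. The compounds shown leave open what concentration of any member is actually tolerated, and whether chloro in place of hydrogen on an aromatic carbon changes it at all: the limit of > 50000 nM in this assay, at which 3 of the 4 values shown sit.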